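Trading a methoxyphenyl for a dimethylphenyl on a chromone core

The source may report more compounds than this note shows. Statements on the series, on what has been measured and on what is new or still open speak of the compounds shown alone.

Of the compounds shown here, two have been measured in a functional assay on KBVIN cells (Homo sapiens) for antiproliferative activity, read by sulforhodamine B assay, with a stated time of 3 days; a higher number here means that more compound is needed for the effect, a lower number that less compound is needed. Compound 1 `CCCCc1ccc(-c2cc(=O)c3c(o2)C(CC)(CC)C(=O)C(CC)=C3O)cc1` carries a butyl-substituted phenyl ring on the shared core and gives 37 uM in this assay. Compound 2 `CCC1=C(O)c2c(oc(-c3cccc(OC)c3)cc2=O)C(CC)(CC)C1=O` carries a 3-methoxyphenyl ring at the same site and gives 1.22 uM, which is the lowest of the two numbers; the gap to compound 1 lies well beyond the scatter of repeat measurements, so compound 2 is clearly the more potent of the pair.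

Compound 3 `CCC1=C(O)c2c(oc(-c3cc(C)ccc3C)cc2=O)C(CC)(CC)C1=O` is a closely related analogue that has not yet been tested. Relative to compound 2, the change is 2,5-dimethylphenyl in place of 3-methoxyphenyl on an aromatic carbon. Among the measured compounds shown here, no pair of measured compounds differs by exactly this change, so the size of the step cannot be read from the data directly. Because compound 2 gives 1.22 uM while compound 1, with a different substituted phenyl ring, gives 37 uM, the author expects a moderate rise in the number for compound 3, likely beyond the scatter, as a 4.1-fold higher number from compound 2 to compound 3 (0.61 log units; beyond the scatter). Compound 3 is therefore estimated at 5 uM, with a range from 1.5 uM to 20 uM.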

Compound 3, concentration for half-maximal effect: 3.41 uM
Beside the measured number, compound 3's estimate is 1.5-fold (0.17 log units) above it; the measured number falls inside the stated range.
By their numbers in this assay, from the lowest: compound 2; then compound 3; then compound 1.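

At this position the aryl group can be exchanged directly, and the step, a 2.8-fold higher number from compound 2 to compound 3 (0.45 log units; beyond the scatter), is a modest one in this assay, even though the entering 2,5-dimethylphenyl has the same number of heavy atoms as the leaving 3-methoxyphenyl but no oxygen and no hydrogen-bond acceptor. The oxygen of the methoxy group is therefore not required for a number of this order, and a ring with two methyl groups is accepted at this aromatic carbon with only a limited cost. The ring of compound 1 also lacks oxygen, yet compound 3 at 3.41 uM stays far closer to compound 2 than to compound 1 at 37 uM, so the lack of oxygen alone does not set the high number of compound 1; nothing available explains why the numbers differ as they do.

Going by these compounds, the change removes a methoxy group and adds two methyl groups in a single step, so the share of each remains unknown, and a plain phenyl ring or a ring carrying a single methyl group would be needed to separate them. On these data alone, it also remains open how this position would respond to an amine or a carboxylic acid on the ring, or to a chain of intermediate length between methyl and butyl.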